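Compound 2 to compound 3: one aromatic substituent exchanged

The compounds below may be only part of what the source reports. "The series", "measured", "known", "first", "only" and "open" are said of these compounds alone.

Of the compounds shown here, two have been measured so far in an ADME assay on cells (Homo sapiens) for cytotoxicity, read by resazurin assay, with a stated time of 5 days; a higher number here means that more compound is tolerated, a lower number that less compound is tolerated. Compound 1 `CCC1=C(C(=O)OCC2CCCCC2)C(c2cccc(O)c2)NC(=O)N1` gives > 10000 nM, and this entry is a limit of the assay, not a number. Going by the values given here, compound 2 `COc1ccc(Nc2nc(CS(=O)(=O)c3cccc(Cl)c3)nc3ccsc23)cc1` gives 60000 nM, the only actual number, so it cannot yet be ranked against a measured neighbour.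

Compound 3 `COc1ccc(-c2nc(CS(=O)(=O)c3cccc(Cl)c3)nc3ccsc23)cn1` keeps the core of compound 2 and changes one group: 6-methoxypyridin-3-yl in place of (4-methoxyphenyl)amino on an aromatic carbon. The 6-methoxypyridin-3-yl group stands in place of (4-methoxyphenyl)amino on an aromatic carbon, next to the ring nitrogen.

Among the compounds with values here, no measured pair shows what such an exchange does in this assay. The expectation therefore rests on compound 2 at 60000 nM and on the size of the change, and no step beyond the usual scatter is expected. The estimated step is a 1.5-fold lower number from compound 2 to compound 3 (0.18 log units; within the scatter). Compound 3 is expected at 40000 nM, with an estimated range of 12000 nM to 100000 nM.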

Compound 3, half-maximal cytotoxic concentration: > 10000 nM
Compound 3: a limit, no number; the forecaster's own chance of this, stated with the estimate: 40%; the middle value does not contradict the limit.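

In this assay compound 3 gives > 10000 nM, which is a limit and not a number, so no step from compound 2 to compound 3 can be read: the limit of > 10000 nM in this assay, at which 2 of the 3 values shown sit.

The compounds shown leave open what 6-methoxypyridin-3-yl in place of (4-methoxyphenyl)amino does in this assay, including whether compound 3 is tolerated to a different concentration than compound 2.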